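A Pentyl Chain on Selenium, Tried a Second Time

A few compounds are considered here, and "the series" means these few. Any claim that something is new, unique, unknown or untested is made for them only; others in the source may bear on it.

In a functional assay on MCF7 cells (Homo sapiens) for cytotoxicity, read by MTT assay, with a stated time of 72 h (a higher number here means a weaker inhibitor of growth, a lower number a stronger inhibitor of growth), compound 1 `CCCCC[Se]c1nc(NCc2ccc(SC)cc2)c2ccccc2n1` gives 65000 nM. Compound 2 `CSc1ccc(CNc2nc([SeH])nc3ccccc23)cc1` does not yield a number in this assay but only the limit of the measurement, > 100000 nM. Compound 3 `Nc1nc([SeH])nc2ncccc12` likewise stops at the limit of this assay, > 100000 nM. Two of the three measured values therefore sit at the limit of > 100000 nM in this assay, at which 2 of the 3 values shown sit.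

The change from compound 2 to compound 1 is pentyl in place of hydrogen on a selenium. The step it made was an at least 1.5-fold lower number from compound 2 to compound 1 (0.18 log units; that floor lies within the scatter); because compound 2 is known only as a limit, the true size of that step could be larger than the floor stated. Compound 3 and compound 2 both carry hydrogen on selenium, but the difference between the two cores is not broken down here.

Compound 4 `CCCCC[Se]c1nc(N)c2cccnc2n1` has not been measured. It differs from compound 3 by pentyl in place of hydrogen on a selenium, the same change as from compound 2 to compound 1. The step expected from compound 3 to compound 4 in this assay is a number no higher from compound 3 to compound 4 (the limit leaves the size open), placed beside the earlier step; it rests on compound 1 having reached 65000 nM after that same change, while the small core of compound 3 gives no number of its own to build on. For compound 4 the estimated value in this assay is 100000 nM, with an expected range from 35000 nM to 300000 nM, and a real chance that only a limit is seen again.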

Compound 4, concentration for total growth inhibition: 53800 nM
Estimate against measurement, compound 4: 1.9-fold (0.27 log units) above; measured number inside the range.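

In this assay pentyl in place of hydrogen on a selenium gave an at least 1.8-fold lower number from compound 3 to compound 4 (0.26 log units; that floor lies within the scatter) and thereby turned a limit into a measured number on a second core. The change therefore carries over in a plain sense, as on each core the compound with hydrogen on selenium stops at the limit while the pentyl compound gives a number: the same change on two cores in this assay, an at least 1.5-fold lower number (0.18 log units; that floor lies within the scatter) from compound 2 to compound 1 and an at least 1.8-fold lower number (0.26 log units; that floor lies within the scatter) from compound 3 to compound 4; the limit leaves it open whether they differ. This does not show that the step has the same size on both cores or how large either step truly is, and it cannot establish a gain beyond the usual scatter, since the two starting points are known only as limits and neither floor clears that scatter: the limit of > 100000 nM in this assay, at which 2 of the 4 values shown sit.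

The compounds shown leave open whether another group on the selenium, such as a butyl chain, a longer hexyl chain or a benzyl group, would lower the number further in this assay than pentyl does. Also open, as far as these compounds go, are what an amine or a carboxylic acid at the end of the chain would do and whether the same change would hold on a third core.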